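Solubility notes: compound 2 to compound 3

The compounds below may be only part of what the source reports. "The series", "measured", "known", "first", "only" and "open" are said of these compounds alone.

Measured in a physicochemical assay for solubility, with a stated time of 24 h, at pH 6.8; a higher number here means a more soluble compound, a lower number a less soluble compound:
- compound 1 `Cc1ccc(COC(=O)N2C[C@@H]3[C@@H](CNC(=O)c4ccc5[nH]c(=O)oc5c4)[C@@H]3C2)nc1`: 56 ug/mL
- compound 2 `N#Cc1cc(COC(=O)N2C[C@@H]3[C@@H](CNC(=O)c4ccc5[nH]nnc5c4)[C@@H]3C2)cc(C(=O)OC(F)(F)F)c1`: < 1 ug/mL

In this assay compound 2 gives only a limit, < 1 ug/mL, and not a number.

Compound 3 `N#Cc1cc(COC(=O)N2C[C@@H]3[C@@H](CNC(=O)N4CCc5[nH]nnc5C4)[C@@H]3C2)cc(C(=O)OC(F)(F)F)c1` differs from compound 2 on a carbonyl carbon, as a group of 9 heavy atoms (5 carbon, 4 nitrogen; one five-membered aromatic ring with 3 hetero atoms, one six-membered non-aromatic ring with 1 hetero atom) in place of a group of 9 heavy atoms (6 carbon, 3 nitrogen; one five-membered aromatic ring with 3 hetero atoms, one six-membered aromatic ring of carbon only), on a carbonyl carbon: a six-membered non-aromatic ring with 1 hetero atom stands in place of a six-membered aromatic ring of carbon only. Going by the values given here, no measured pair isolates this change. The expected step in this assay is upward and modest, beyond the scatter, though only roughly estimated: an at least 4.0-fold higher number from compound 2 to compound 3 (0.60 log units; beyond the scatter). For compound 3 the estimated value is 4 ug/mL, with an expected range of 1 ug/mL to 20 ug/mL.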

Compound 3, solubility: 5 ug/mL
Compound 3: middle estimate off by 1.3-fold (0.10 log units), on the low side, within the range that was stated.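

With the rest of the molecule unchanged, this assay shows an at least 5.0-fold higher number from compound 2 to compound 3 (0.69 log units; beyond the scatter) when a six-membered non-aromatic ring with 1 hetero atom stands in place of a six-membered aromatic ring of carbon only, on a carbonyl carbon. This position therefore accepts the change and gives a readable number. The true size of the step remains unknown, with only its lower bound given: the limit of < 1 ug/mL in this assay, at which 1 of the 3 values shown sits.

The compounds shown do not separate the loss of the aromatic ring from the arrival of the amide-type nitrogen on the carbonyl carbon. Going by these compounds, how this assay would read with an amine or a carboxylic acid on the non-aromatic ring stays open.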